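Moving the Chlorine Around the Benzyl Ring

This account rests on a few compounds, and the source may have more. Where it says the series, first, only, none or still open, it means among the compounds named here.

Compound 1 `CC1=C(C(=O)Nc2ccc(Br)cc2)C(c2ccc(Cl)cc2Cl)N=C(SCc2ccccc2)N1` gives 17.4% in a functional assay on the whole organism (artery, strain albino) with Rattus norvegicus as the target, with a stated time of 600 min, at a dose of 10 mg/kg by the oral route; on this read-out lower numbers stand for less inhibition and higher numbers for more inhibition at the one dose given (going by the name of the read-out).
Compound 2 `CC1=C(C(=O)Nc2ccc(Br)cc2)C(c2ccc(Cl)cc2Cl)N=C(SCc2ccccc2Cl)N1` gives 24.6% in this assay.
Compound 3 `CC1=C(C(=O)Nc2ccc(Br)cc2)C(c2ccc(Cl)cc2Cl)N=C(SCc2cccc(Cl)c2)N1` gives 15.4% in this assay.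

On the numbers shown, compound 3 sits nearest compound 1 and furthest from compound 2: the steps are a number 2 percentage points lower from compound 1 to compound 3 (within the scatter) and a number 9.2 percentage points lower from compound 2 to compound 3 (within the scatter), both within the scatter, so the three measured compounds cannot be told apart on this read-out. The two chlorine additions to the shared core, a number 7.2 percentage points higher from compound 1 to compound 2 (within the scatter) and a number 2 percentage points lower from compound 1 to compound 3 (within the scatter), likewise stayed within the scatter.

Compound 4 `CC1=C(C(=O)Nc2ccc(Br)cc2)C(c2ccc(Cl)cc2Cl)N=C(SCc2ccc(Cl)cc2)N1` has not been measured. Its difference from compound 3 is 4-chlorophenyl in place of 3-chlorophenyl on a saturated chain carbon bound to a sulfur. The step that bears most directly on it is the one that already moved the chlorine on the same ring, a number 9.2 percentage points lower from compound 2 to compound 3 (within the scatter), which stayed within the scatter; the steps of a number 7.2 percentage points higher from compound 1 to compound 2 (within the scatter) and a number 2 percentage points lower from compound 1 to compound 3 (within the scatter) point the same way. For the measured compounds named here, no measured step has gone beyond the scatter, so for compound 4 the expected step is a number 2.6 percentage points higher from compound 3 to compound 4 (within the scatter), that is, none beyond the scatter in either direction. Compound 4 is therefore estimated at 18%, with a range from 8% to 30%.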

Compound 4, a percentage reported as inhibition, in the whole organism at one dose (the size of the read-out at that dose, not a potency): 30.3%
The estimate for compound 4 lay 12.3 percentage points below the measured number, outside the stated range (above it).
By their numbers in this assay, from the lowest: compounds 3, 1, 2 and 4 (each within the scatter of the next, the first and the last beyond it).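

For the compounds shown here, at the position on a saturated chain carbon bound to a sulfur, 4-chlorophenyl in place of 3-chlorophenyl gives the first step beyond the scatter in this assay (a number 14.9 percentage points higher from compound 3 to compound 4 (beyond the scatter)), although it is modest, and chloro in place of hydrogen on an aromatic carbon now also clears the scatter when it gives the 4-chlorobenzyl compound (a number 12.9 percentage points higher from compound 1 to compound 4 (beyond the scatter)). The earlier chlorine changes had not shown this, so the placing of one chlorine on this ring can register on this read-out even with the same atoms, but the 2-chlorophenyl and 4-chlorophenyl compounds cannot be told apart (a number 5.7 percentage points higher from compound 2 to compound 4 (within the scatter), within the scatter). Nothing available gives a reason for these differences.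

From the compounds shown here alone, whether 4-fluorophenyl or 4-methoxyphenyl at this place would give a number like that of compound 4 remains open, as does the effect of a longer chain between the sulfur and the ring. The single dose and single time also leave open whether the separation of these compounds would hold at other doses or times.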